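This account rests on a few compounds, and the source may have more. Where it says the series, first, only, none or still open, it means among the compounds named here.

In an assay on membranes from brain for displacement of a labelled ligand from Sigma non-opioid intracellular receptor 1 (Cavia porcellus), read by scintillation counting, with a stated time of 120 min (on this read-out lower numbers stand for stronger inhibition and higher numbers for weaker inhibition), compound 1 `CN(CCCc1ccccc1)C1CCc2ccsc2CC1` gives 10 nM, while compound 2 `OCc1cc2c(s1)CCC(NCCCc1ccccc1)CC2` gives 61 nM, the higher of the two numbers, a gap beyond the usual scatter. Compound 3 `CN(CCCc1ccccc1)C1CCc2cc(CO)sc2CC1` arises from compound 2 by one change: methyl in place of hydrogen on an amine nitrogen. For the measured compounds named here, no measured pair shows this change alone, so its size is open. Going by the values given here, the only hint is compound 1, which also carries a methyl on its amine nitrogen and gives 10 nM. On that hint a moderate fall in this assay is expected, a 2.4-fold lower number from compound 2 to compound 3 (0.39 log units; beyond the scatter). Compound 3 is estimated at 25 nM, with a range from 8 nM to 80 nM.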

Compound 3, inhibition constant: 6.4 nM
Beside the measured number, compound 3's estimate is 3.9-fold (0.59 log units) above it; the measured number lies below the stated range.
By their numbers in this assay, from the lowest: compounds 3 and 1 (each within the scatter of the next); then compound 2.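

In this assay, methyl in place of hydrogen on an amine nitrogen gives a 9.5-fold lower number from compound 2 to compound 3 (0.98 log units; beyond the scatter), the first direct sign that this single change matters when the rest of the structure stays the same. Hydroxymethyl in place of hydrogen on an aromatic carbon gives only a 1.6-fold lower number from compound 1 to compound 3 (0.19 log units; within the scatter), so with methyl on the nitrogen this group makes no clear difference. Nothing available explains the size of the methyl step.

Going by these compounds, whether ethyl or a longer chain on the nitrogen would fare like methyl remains open. So does whether hydroxymethyl would matter with hydrogen on that nitrogen.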